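The source may hold more compounds than are shown below. What is called first, only, known or untested is meant among the compounds shown, and "the series" means these compounds.

Compound 2 `Cc1cccc(C)c1-c1cccc(COc2ccc(CCC(=O)O)s2)c1` stands at the low end of the three numbers measured in a functional assay on cells for agonist activity at Free fatty acid receptor 1 (Homo sapiens), read by calcium flux (a lower number here means that less compound is needed, a higher number that more compound is needed for the effect), where compound 2 gives 32 nM. Compound 1 `Cc1cccc(C)c1-c1cccc(COc2cn(CCC(=O)O)nn2)c1` has a core that differs from that of compound 2; in this assay compound 1 gives 14800 nM, and compound 3 `Cc1cccc(C)c1-c1cccc(COc2ccc(CC3SC(=O)NC3=O)s2)c1` gives 82 nM. Going by the values given here, the one step between two compounds that differ in a single place runs a 2.6-fold higher number from compound 2 to compound 3 (0.41 log units; beyond the scatter), a change at the acid end of the molecule.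

Compound 4 `COc1ccc(F)c(-c2cccc(COc3ccc(CCC(=O)O)s3)c2)c1` is not yet measured. It differs from compound 2 in the other end of the structure: 2-fluoro-5-methoxyphenyl in place of 2,6-dimethylphenyl on an aromatic carbon. Among the compounds with values here, none of the measured steps concerns this end of the molecule, so the measured step from compound 2 to compound 3 gives no direct guide, and the effect of the change is open. On the ground that both ends of the shared core of compound 2 can tolerate change without loss of the order seen for compound 1, a modest rise in number is expected, a 2.8-fold higher number from compound 2 to compound 4 (0.45 log units; beyond the scatter), so that compound 4 is estimated at 90 nM, within a range from 20 nM to 500 nM.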

Compound 4, half-maximal effective concentration: 580 nM
For compound 4 the middle estimate is 6.4-fold (0.81 log units) below the measured one, and the stated range ends below it.
By their numbers in this assay, from the lowest: compound 2; then compound 3; then compound 4; then compound 1.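

In this assay, the change of 2,6-dimethylphenyl to 2-fluoro-5-methoxyphenyl gives an 18-fold higher number from compound 2 to compound 4 (1.26 log units; beyond the scatter) and is a large step, so this end of the shared core is far from indifferent to what it carries. This step is larger than the single step at the acid end, a 2.6-fold higher number from compound 2 to compound 3 (0.41 log units; beyond the scatter), so among the changes shown, the one at this position moves the number more. Nothing available here explains the size of the step.

The swap removes two methyl groups and brings in a fluorine and a methoxy group at once, so what the compounds shown leave open is whether a phenyl ring carrying only fluorine, only methoxy or only one methyl group would account for the rise. Also open, as far as these compounds go, is whether the same change would act alike with the 2,4-dioxo-1,3-thiazolidin-5-yl group of compound 3 at the acid end.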